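This account rests on a few compounds, and the source may have more. Where it says the series, first, only, none or still open, it means among the compounds named here.

Three compounds of this series have a number in an assay on HEK293 cells for binding affinity to 5-hydroxytryptamine receptor 7 (Homo sapiens), read by radioligand binding, tested at 1 uM; on this read-out higher numbers stand for more inhibition at the one concentration tested (going by the name of the read-out) and lower numbers for less inhibition. Compound 1 `Brc1ccc2ccn(CCN3CCC4CCCCN4CC3)c2c1` gives 71%, compound 2 `CCc1ccc2ccn(CCN3CCCN(C)CC3)c2c1` gives 66%, and compound 3 `CC(C)N1CCCN(CCn2ccc3ccc(Br)cc32)CC1` gives 92%, the highest of the three; its nearest neighbour is compound 1, lower by an amount beyond the scatter, and compound 2 lies further below, also beyond the scatter. Compound 4 `Brc1ccc2ccn(CCN3CCCN(CC4CC4)CC3)c2c1` differs from compound 3 in one place: cyclopropylmethyl in place of isopropyl on an amine nitrogen in a ring. For the measured compounds named here, no step between two measured compounds isolates a change of this kind, so the size of the step is uncertain. Compound 4 is expected to stay near compound 3, with a step of a number 7 percentage points lower from compound 3 to compound 4 (within the scatter) that is small and most likely within the scatter. The estimate for compound 4 in this assay is 85%, with a range from 65% to 97%.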

Compound 4, a percentage reported as inhibition, at one concentration (the size of the read-out at that concentration, not a potency): 95%
The estimate for compound 4 lay 10 percentage points below the measured number; low and high end bracket the measured number.
By their numbers in this assay, from the lowest: compounds 2 and 1 (each within the scatter of the next); then compounds 3 and 4 (each within the scatter of the next).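

In this assay, cyclopropylmethyl in place of isopropyl on the ring amine nitrogen gives a number 3 percentage points higher from compound 3 to compound 4 (within the scatter). At this position, the series therefore accepts a three-membered ring and 4 heavy atoms in place of 3 without a readable change at the one concentration tested. No available measurement bears on why this step is so small.

The compounds shown leave open whether a benzyl group or a 2-hydroxyethyl chain on this nitrogen would hold the number. They also leave open whether the step carries over to a core with ethyl in place of bromine.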